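Adding a methoxy group to compound 2

The compounds below may be only part of what the source reports. "The series", "measured", "known", "first", "only" and "open" are said of these compounds alone.

Two close relatives set the scene here, and only one of them has a number. In an ADME assay on J774.A1 cells (Mus musculus) for cytotoxicity, read by MTT assay, with a stated time of 48 h (on this read-out higher numbers stand for lower toxicity in this test and lower numbers for higher toxicity in this test), compound 1 `COc1ccc(CNC(=O)c2c([N+](=O)[O-])noc2-c2ccc(Cl)cc2)cc1` gives 89500 nM. Compound 2 `O=C(NCc1ccccc1)c1c([N+](=O)[O-])noc1-c1ccc(Cl)cc1Cl` has no standing on this scale at all: in this assay, compound 2 stands as "not determined" (no result reported). It therefore cannot serve as a measured starting point.

The change under study is small: methoxy in place of hydrogen on an aromatic carbon. This puts methoxy in place of hydrogen on an aromatic carbon, para to a large group, so that benzyl becomes 4-methoxybenzyl. The product is compound 3 `COc1ccc(CNC(=O)c2c([N+](=O)[O-])noc2-c2ccc(Cl)cc2Cl)cc1`.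

Among the compounds with values here, no measured pair shows what this change does in this assay, so the data give no size or direction for the step. The expectation is therefore a step no larger than the usual scatter, with no direction favoured. The only anchor for the estimate is compound 1 at 89500 nM, and the range stays wide to reflect that. For compound 3, the expected half-maximal cytotoxic concentration is estimated at 70000 nM, within a range of 25000 nM to 190000 nM.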

Compound 3, half-maximal cytotoxic concentration: 80500 nM
For compound 3 the middle estimate is 1.2-fold (0.06 log units) below the measured one; the measured number falls inside the stated range.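

In this assay, within the data shown here, the only step that can be read is a 1.1-fold lower number from compound 1 to compound 3 (0.05 log units; within the scatter) for chloro in place of hydrogen on an aromatic carbon, so with the 4-methoxybenzyl group present on both compounds, this extra chloro leaves the two numbers indistinguishable. Among these compounds, the step this piece set out to follow, from benzyl to 4-methoxybenzyl, still cannot be read, as compound 2 has no number, and compound 3 shows only that a compound carrying methoxy at this position and both chloro groups has a measured value on this scale. Nothing available here bears on what lies behind this result.

A measured compound with benzyl and the same two chloro groups would be needed to give the methoxy change a size and a direction. It also stays open how this position would respond to a different group in place of methoxy, such as an amine, a carboxylic acid or a longer chain like butoxy, as the compounds shown carry only methoxy there.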